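From Ethyl to Fluoro: What Compound 4 May Show

A few compounds are considered here, and "the series" means these few. Any claim that something is new, unique, unknown or untested is made for them only; others in the source may bear on it.

In a functional assay on A549 cells (Homo sapiens) for inhibition, read by CCK-8 assay, with a stated time of 72 h, tested at 2 uM (on this read-out higher numbers stand for more inhibition of growth at the one concentration tested and lower numbers for less inhibition of growth), compound 2 (`CCc1ccc(SCc2ccc(C(=O)Nc3ccccc3N)cc2)cc1`) gives 53.6%. Compound 1 (`Nc1ccccc1NC(=O)/C=C/c1ccc(CSc2cccc(F)c2)cc1`) gives 50.7%, which lies within the usual scatter of the number for compound 2. For the measured compounds named here, compound 3 (`Cc1ccc(SCc2ccc(/C=C/C(=O)Nc3ccccc3N)cc2)cc1`) gives 43.4%, and the gap between that number and the one for compound 2 goes beyond the scatter.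

Compound 4 (`Nc1ccccc1NC(=O)c1ccc(CSc2ccc(F)cc2)cc1`) has not yet been measured. It differs from compound 2 in one place: fluoro in place of ethyl on an aromatic carbon. In other words, 4-ethylphenyl becomes 4-fluorophenyl.

Going by the values given here, only one measured step touches a comparable spot, the ring on the sulfur, and it comes from a different core. Replacing 3-fluorophenyl with 4-methylphenyl gave a number 7.3 percentage points lower from compound 1 to compound 3 (within the scatter), a change within the scatter. On that single small step, no change beyond the scatter is expected in this assay. The estimated change is a number 3.6 percentage points lower from compound 2 to compound 4 (within the scatter), which is no real shift. For compound 4 the expected value is 50%, with an estimated range from 38% to 62%.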

Compound 4, percent growth inhibition at one concentration: 43.4%
Estimate against measurement, compound 4: 6.6 percentage points above; the range from low to high includes it.
By their numbers in this assay, from the lowest: compounds 3, 4, 1 and 2 (each within the scatter of the next, the first and the last beyond it).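

In this assay, putting fluoro in place of ethyl on an aromatic carbon, para to a large group, gave a number 10.2 percentage points lower from compound 2 to compound 4 (beyond the scatter) and so moved the number beyond the usual scatter. For the compounds shown here, the earlier change on the ring on the sulfur, made on a different core and at a different ring position, stayed within it, with a number 7.3 percentage points lower from compound 1 to compound 3 (within the scatter) as its step, so this is the first sign that the group at this spot can matter, although the step is modest and rests on a single pair. Nothing measured here gives a reason for the drop.

From the compounds shown here alone, it remains open whether a longer chain, a methoxy group or an amine at this spot would keep the number of compound 2 or lower it. Going by these compounds, it is also open whether the same swap would give a similar step on the core of compound 1.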